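This account rests on a few compounds, and the source may have more. Where it says the series, first, only, none or still open, it means among the compounds named here.

Three compounds built on the same core differ only in the group attached to a saturated chain carbon bound to a sulfur. Compound 1 `Cc1cc(Nc2cc(-c3ccccc3)[nH]n2)n2nc(SCc3csc4ccccc34)nc2n1` carries 1-benzothiophen-3-yl there and, in an ADME assay on GES1 cells (Homo sapiens) for inhibition, read by MTT assay, with a stated time of 72 h (a lower number here means a stronger inhibitor, a higher number a weaker inhibitor), compound 1 gives 29200 nM. Compound 2 `Cc1cc(Nc2cc(-c3ccccc3)[nH]n2)n2nc(SCc3ccc(C(F)(F)F)cc3)nc2n1` carries 4-(trifluoromethyl)phenyl, and compound 2 gives 42700 nM. Compound 3 `Cc1cc(Nc2cc(-c3ccccc3)[nH]n2)n2nc(SCc3ccccc3Br)nc2n1` carries 2-bromophenyl, and compound 3 gives 41100 nM, which places compound 3 second highest of the three numbers, with compound 2 nearest and compound 1 furthest, every gap within the scatter. The steps among them, a 1.5-fold higher number from compound 1 to compound 2 (0.17 log units; within the scatter), a 1.4-fold higher number from compound 1 to compound 3 (0.15 log units; within the scatter) and a 1.0-fold lower number from compound 2 to compound 3 (0.02 log units; within the scatter), show that exchanging one ring for another at this place has not moved the number beyond the scatter.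

Compound 4 `CCCSc1nc2nc(C)cc(Nc3cc(-c4ccccc4)[nH]n3)n2n1` goes further: ethyl in place of 2-bromophenyl on a saturated chain carbon bound to a sulfur so that the ring disappears altogether and the attachment becomes propylsulfanyl in place of (2-bromobenzyl)sulfanyl. Within the data shown here, no measured pair shows what losing the ring does, so the three small steps bear on compound 4 only loosely. Because steps such as a 1.5-fold higher number from compound 1 to compound 2 (0.17 log units; within the scatter) stayed within the scatter, the number for compound 4 is expected to change little, a 1.1-fold higher number from compound 3 to compound 4 (0.04 log units; within the scatter). For compound 4 the estimate in this assay is 45000 nM, within a range from 18000 nM to 110000 nM.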

Compound 4, half-maximal inhibitory concentration: > 50000 nM
Compound 4 was reported as a limit; the forecaster's own chance of this, stated with the estimate: 20%; at least 1.1-fold (0.04 log units) between middle value and limit.
By their numbers in this assay, from the lowest: compounds 1, 3 and 2 (each within the scatter of the next). At a limit, above all of these: compound 4.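

The reading for compound 4 in this assay is a limit of the assay and not a number: the limit of > 50000 nM in this assay, at which 1 of the 4 values shown sits. It gives the first view of this position with the ring gone, as the change from 2-bromobenzyl to propyl gives an at least 1.2-fold higher number from compound 3 to compound 4 (0.08 log units; that floor lies within the scatter), while the same replacement of the other two rings gives an at least 1.1-fold higher number from compound 2 to compound 4 (0.06 log units; that floor lies within the scatter) and an at least 1.7-fold higher number from compound 1 to compound 4 (0.23 log units; that floor lies within the scatter). Each of these is only a floor lying within the scatter, so the result shows that removing the ring did not bring the number down, but it cannot show how far the number rose, and the ring may matter little or a great deal here.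

The compounds shown leave open where the true value of compound 4 lies, and so whether the small propyl group truly differs from the three ring-bearing groups. They also leave open what a plain unsubstituted phenyl, a longer chain such as hexyl, or a chain ending in an amine or a carboxylic acid would give on the saturated chain carbon bound to a sulfur.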